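The source may hold more compounds than are shown below. What is called first, only, known or untested is meant among the compounds shown, and "the series" means these compounds.

Compounds measured so far:

Compound 1 `Cc1cnc(CN2CC(=O)N(CC(C)C)c3c(Cl)nc(N)nc32)c(C)c1Br` — 280 nM
Compound 2 `COc1c(C)cnc(CN2CC(=O)N(C(C)C)c3c(Cl)nc(N)nc32)c1C` — 50 nM
Compound 3 `COc1c(C)cnc(CN2c3nc(N)nc(Cl)c3NC(=O)[C@@H]2C)c1C` — 940 nM

These three compounds were tested in a functional assay on MCF7 cells (Homo sapiens) for inhibition; a higher number here means a weaker inhibitor, a lower number a stronger inhibitor. Compound 2 stands lowest of the three numbers, and so is the strongest inhibitor here: compound 1 sits beyond the scatter above it, and compound 3 sits further still, also beyond the scatter. Compound 1 and compound 3 each differ from compound 2 in more than one place, so no single structural change can be read from their values.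

The next compound, compound 4 `COc1c(C)cnc(CN2CC(=O)N(C)c3c(Cl)nc(N)nc32)c1C`, differs from compound 2 in one place only (methyl in place of isopropyl on an amide-type nitrogen in a ring). For the measured compounds named here, no pair among the measured compounds shows this change, so there is no measured step to lean on. The small group entering has fewer atoms than the group leaving, and changes of this kind at an amide-type nitrogen in a ring have not been sampled here. The expectation is a modest move toward a higher number, a step from compound 2 to compound 4 that is estimated as a 2.4-fold higher number from compound 2 to compound 4 (0.38 log units; beyond the scatter), which may well lie within the scatter.

For compound 4 in this assay the estimated value is 120 nM, with a range from 40 nM to 400 nM.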

Compound 4, half-maximal inhibitory concentration: 2190 nM
Beside the measured number, compound 4's estimate is 18-fold (1.26 log units) below it; the measured number lies above the stated range.
By their numbers in this assay, from the lowest: compound 2; then compound 1; then compound 3; then compound 4.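

In this assay, for the compounds shown here, swapping isopropyl for methyl on the amide-type nitrogen in a ring gives a 44-fold higher number from compound 2 to compound 4 (1.64 log units; beyond the scatter), the first step here that can be read at a single place. It shows that this position is far from indifferent: the group shrinks from 3 heavy atoms to 1 heavy atom, neither group has a hydrogen-bond donor or acceptor, neither carries a net charge, and yet the inhibition of the cells is much weaker with methyl. Nothing available here accounts for why so small a change has so large an effect.

With only two groups compared at this one place, the step gives a direction between isopropyl and methyl but no trend, and the compounds shown leave open how a plain hydrogen on that nitrogen, a cyclopropyl ring, or a longer chain ending in an amine would compare with compound 2. Compound 1 has a different group there, but it also differs from compound 2 elsewhere on the pyridine-free reading of its substituents, so it cannot settle this.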